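Removing the 4-methylphenoxy group from compound 2

The source may report more compounds than this note shows. Statements on the series, on what has been measured and on what is new or still open speak of the compounds shown alone.

Among the compounds with values here, in a functional assay on A549 cells (Homo sapiens) for antiproliferative activity, read by MTT assay, with a stated time of 48 h (on this read-out lower numbers stand for stronger inhibition of growth and higher numbers for weaker inhibition of growth), compound 2 (`Cc1ccc(OCCCCN(Cc2ccc(C(=O)NO)cc2)c2ncc(-c3ccc(C)cc3)s2)cc1`) gives 8630 nM, the lower of the two numbers so far, while compound 1 (`Cc1ccc(-c2cnc(N(Cc3ccc(C(=O)NO)cc3)CC(C)C)s2)cc1`) gives 20400 nM. Compound 3 (`CCCCN(Cc1ccc(C(=O)NO)cc1)c1ncc(-c2ccc(C)cc2)s1`) has hydrogen in place of 4-methylphenoxy on a saturated chain carbon, four bonds along the chain from a nitrogen on an aromatic ring. Within the data shown here, one measured step bears on this change: a 2.4-fold lower number from compound 1 to compound 2 (0.37 log units; beyond the scatter), a modest gain that came with 3-(4-methylphenoxy)propyl in place of isopropyl. The new change removes the 4-methylphenoxy group again, so a modest step of similar size towards a higher number is expected in this assay, although a single step is thin evidence. The expected change is a 2.0-fold higher number from compound 2 to compound 3 (0.29 log units; within the scatter). The estimate for compound 3 is 17000 nM, with a likely range from 8000 nM to 35000 nM.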

Compound 3, concentration for 50% growth inhibition: 4780 nM
Beside the measured number, compound 3's estimate is 3.6-fold (0.55 log units) above it; measured number outside the range, below it.
By their numbers in this assay, from the lowest: compounds 3 and 2 (each within the scatter of the next); then compound 1.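

In this assay the change at this position gives a 1.8-fold lower number from compound 2 to compound 3 (0.26 log units; within the scatter) and so the 4-methylphenoxy group can be removed from the chain without a difference that this read-out can separate from scatter. The comparison with the branched chain gives a 4.3-fold lower number from compound 1 to compound 3 (0.63 log units; beyond the scatter) with propyl in place of isopropyl on a saturated chain carbon bound to a nitrogen on an aromatic ring, which shows that the gain over compound 1 does not require the 4-methylphenoxy group. No evidence at hand explains either result.

From the compounds shown here alone, it remains open whether a longer plain chain would keep compound 3's level of growth inhibition. Going by these compounds, it is also open how an amine or a carboxylic acid at the end of the chain would change the number.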